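A few compounds are considered here, and "the series" means these few. Any claim that something is new, unique, unknown or untested is made for them only; others in the source may bear on it.

Measured compounds in an assay for binding affinity to Neuropeptide Y receptor type 1 (Homo sapiens), read by radioligand binding; a lower number here means a stronger inhibitor, a higher number a weaker inhibitor:
- Compound 1, `COc1ccc(S(=O)(=O)c2cc(N)c3ncccc3c2[N+](=O)[O-])cc1`: 1140 nM
- Compound 2, `Nc1cc(S(=O)(=O)c2ccc(Cl)cc2)c([N+](=O)[O-])c2cccnc12`: 1750 nM
- Compound 3, `Nc1cc(S(=O)(=O)c2cccc(Cl)c2)c([N+](=O)[O-])c2cccnc12`: 892 nM

Compound 3 holds the lowest of the three numbers, but its separation from the others is small: a 1.3-fold lower number from compound 1 to compound 3 (0.11 log units; within the scatter) and a 2.0-fold lower number from compound 2 to compound 3 (0.29 log units; within the scatter). The three steps among the measured compounds are all within the scatter, including a 1.5-fold higher number from compound 1 to compound 2 (0.19 log units; within the scatter) on the aromatic carbon. Across this set, exchanging the ring attached to the sulfonyl sulfur has moved the number in this assay only a little.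

Compound 4, `Nc1cc(S(=O)(=O)c2ccccc2Br)c([N+](=O)[O-])c2cccnc12`, not yet measured, differs from compound 3 at the same position: 2-bromophenyl in place of 3-chlorophenyl on a sulfonyl sulfur. The leaving group carries one chlorine, the entering group one bromine; otherwise both are six-membered aromatic rings of carbon only, with no donors or acceptors and no net charge. Going by the values given here, no measured pair shows a bromine-bearing ring or this substitution pattern, so the bearing steps are only the aryl exchanges 1>3 and 2>3, both within the scatter. On that basis the number for compound 4 is expected to sit in the same narrow band, with a step of about a 1.3-fold higher number from compound 3 to compound 4 (0.13 log units; within the scatter), that is, no change beyond the scatter. Compound 4 is therefore estimated at 1200 nM, with a range from 400 nM to 3500 nM.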

Compound 4, inhibition constant: 234 nM
Beside the measured number, compound 4's estimate is 5.1-fold (0.71 log units) above it, and the stated range ends above it.
By their numbers in this assay, from the lowest: compound 4; then compounds 3, 1 and 2 (each within the scatter of the next).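

In this assay, the ring on the sulfonyl sulfur can move the number beyond the scatter: there is a 3.8-fold lower number from compound 3 to compound 4 (0.58 log units; beyond the scatter), along with a 7.5-fold lower number from compound 2 to compound 4 (0.87 log units; beyond the scatter) and a 4.9-fold lower number from compound 1 to compound 4 (0.69 log units; beyond the scatter). Going by these compounds alone, the exchanges among compound 1, compound 2 and compound 3 all stayed within the scatter, so this position is more responsive than those three alone suggested, and compound 4 is the only compound with steps to all the others printed as beyond it. Nothing available here bears on what lies behind this change.

Still open, as far as these compounds go, is whether the shift belongs to the bromine or to its placement on the ring; a 2-chlorophenyl or a 3-bromophenyl group would separate the two. Also open, from the compounds shown here alone, is how a non-aromatic group on the sulfonyl sulfur, such as an amine or a longer chain, would read in this assay.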